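This account rests on a few compounds, and the source may have more. Where it says the series, first, only, none or still open, it means among the compounds named here.

In a toxicity assay on the whole organism (H4IIE cells) for cytotoxicity, with Rattus norvegicus as the target, read by MTT assay, with a stated time of 24 h, tested at 0.3 uM (on this read-out lower numbers stand for a stronger effect and higher numbers for a weaker effect at the one concentration tested), compound 2, `Cc1ccc(C(C)C)cc1OC(=O)NC1CCCC1`, gives 71.1%, the highest of the two numbers available; compound 1, `Cc1ccc(C(C)C)c(OC(=O)Nc2ccc([N+](=O)[O-])cc2)c1`, gives 54.4%, a gap beyond the usual scatter. Compound 3, `Cc1ccc(C(C)C)cc1OC(=O)Nc1cccc(F)c1`, has not yet been measured in this assay. The change from compound 2 is 3-fluorophenyl in place of cyclopentyl on an amide-type nitrogen. Among the compounds with values here, with no measured step of this kind to lean on, the expected step of a number 10.1 percentage points lower from compound 2 to compound 3 (beyond the scatter) is a moderate move downward, towards the value of compound 1, since compound 1 also carries an aromatic group at this nitrogen. Compound 3 is therefore expected to give about 61%, between 46% and 78%.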

Compound 3, a percentage reported as activity, at one concentration (the size of the read-out at that concentration, not a potency): 74.1%
The estimate for compound 3 lay 13.1 percentage points below the measured number; the measured number falls inside the stated range.
By their numbers in this assay, from the lowest: compound 1; then compounds 2 and 3 (each within the scatter of the next).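

In this assay, placing 3-fluorophenyl instead of cyclopentyl on the amide-type nitrogen gives a number 3 percentage points higher from compound 2 to compound 3 (within the scatter) and so separates compound 2 and compound 3 by no more than the usual scatter. At this position, then, an aromatic ring carrying fluorine and a non-aromatic carbon ring read alike on the shared core. Nothing measured here accounts for this result.

Still open, as far as these compounds go, is how a plain phenyl, a longer chain or a ring bearing a carboxylic acid would read on this nitrogen.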